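A few compounds are considered here, and "the series" means these few. Any claim that something is new, unique, unknown or untested is made for them only; others in the source may bear on it.

Compound 2 `CCS(=O)(=O)CCOCn1cc[n+](C)c1/C=N/O`: < -2.7
Compound 1 `CC(OCn1cc[n+](C)c1/C=N/O)C(C)S(C)(=O)=O`: -2.09; -2.79 (2 entries)

In a physicochemical assay for lipophilicity (on this read-out higher numbers stand for higher lipophilicity and lower numbers for lower lipophilicity), compound 2 gives only a limit, < -2.7, and no single number. That limit is the lower edge of what this measurement reports, as the limit of < -2.7 in this assay, at which 1 of the 2 values shown sits, shows. Among the compounds with values here, compound 1 is a different compound with no single-point step to compound 2. In this assay compound 1 gives -2.09; -2.79 (2 entries), and its two entries the several entries of compound 1 in this assay, -2.09; -2.79 (2 entries) spread more widely than the usual scatter of this kind of measurement.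

Compound 3 `CCS(=O)(=O)CC(C)OCn1cc[n+](C)c1/C=N/O` has not yet been measured in this assay. It differs from compound 2 in one place: methyl in place of hydrogen on a saturated chain carbon bound to an oxygen on a saturated carbon and a saturated chain carbon.

Within the data shown here, no measured pair shows the effect of exactly this change. A small step upward in this assay is expected, close to the edge of the scatter, so that a number at least 0.20 log units higher from compound 2 to compound 3 (that floor lies within the scatter) is the expected change from compound 2 to compound 3. For compound 3 the expected value in this assay is -2.5, within a range from -2.95 to -2.05.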

Compound 3, distribution coefficient: -2.7
Estimate against measurement, compound 3: 0.20 log units above; the range from low to high includes it.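

In this assay, methyl in place of hydrogen on a saturated chain carbon bound to an oxygen on a saturated carbon and a saturated chain carbon gives a number no lower from compound 2 to compound 3 (the limit leaves the size open), the first view of this change from two compounds that differ in one place. Compound 2 gives < -2.7, which is a limit and not a number. Compound 3 gives a single number, but it falls at the same figure, so the direction of the step can be stated while its size cannot be read, and the reading rests on this point: the limit of < -2.7 in this assay, at which 1 of the 3 values shown sits.

As far as these compounds go, the true size of the methyl step stays open, and a single entry for compound 3 is a thin basis on a read-out where repeated entries for one compound can differ by more than the usual scatter: the several entries of compound 1 in this assay, -2.09; -2.79 (2 entries). Also open is how the read-out would respond to a longer chain or an amine at this same place on the saturated chain, or to a second methyl there, since the compounds shown include no such pair.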